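The compounds below may be only part of what the source reports. "The series", "measured", "known", "first", "only" and "open" are said of these compounds alone.

Among the compounds with values here, the two compounds measured so far share one core. Compound 1 `Cc1ccc2nc(Cl)c(/C=N/n3cc(-c4ccccc4)nc3N)cc2c1` carries a phenyl group on the five-membered ring, and in a functional assay on HCT-116 cells (Homo sapiens) for cytotoxicity, read by MTT assay, with a stated time of 48 h (a higher number here means a weaker inhibitor, a lower number a stronger inhibitor), compound 1 gives 7120 nM. Compound 2 `Cc1ccc2nc(Cl)c(/C=N/n3cc(-c4ccc(Cl)cc4)nc3N)cc2c1` carries a 4-chlorophenyl group in the same place. In this assay compound 2 gives only a limit, > 50000 nM, so no exact number is known for it. The step of an at least 7.0-fold higher number from compound 1 to compound 2 (0.84 log units; beyond the scatter) is thus known only as a lower bound, set by the limit of > 50000 nM in this assay, at which 1 of the 2 values shown sits.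

Compound 3 `Cc1ccc2nc(Cl)c(/C=N/n3cc(-c4cccc5ccccc45)nc3N)cc2c1` is the compound still to be measured: naphthalen-1-yl in place of 4-chlorophenyl on an aromatic carbon. Within the data shown here, no measured step bears on this change directly, since the only step recorded, an at least 7.0-fold higher number from compound 1 to compound 2 (0.84 log units; beyond the scatter), concerns chloro in place of hydrogen and ends at a compound whose value is a limit. Naphthalen-1-yl does not appear among the measured compounds, and the only firm number available is that of compound 1 in this assay, 7120 nM. The estimate for compound 3 is therefore wide and leans on that single point. Compound 3 is expected to give 20000 nM, within 5000 nM to 80000 nM. The expected step of an at least 2.5-fold lower number from compound 2 to compound 3 (0.39 log units; beyond the scatter) is uncertain in direction, and a limit again would not be surprising.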

Compound 3, half-maximal inhibitory concentration: 5840 nM
The estimate for compound 3 lay 3.4-fold (0.53 log units) above the measured number, and the stated range covers the measured number.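

Replacing phenyl with naphthalen-1-yl leaves the read-out in this assay essentially unchanged, as the step is a 1.2-fold lower number from compound 1 to compound 3 (0.09 log units; within the scatter), so this aromatic carbon of the five-membered ring can carry the two-ring group without a change beyond the scatter. Compound 2 gives only a limit, > 50000 nM, and not an exact number. The step of an at least 8.5-fold lower number from compound 2 to compound 3 (0.93 log units; beyond the scatter) shows that the loss seen with 4-chlorophenyl does not come with every larger group here, since naphthalen-1-yl has 10 heavy atoms against 7, though this step is known only as a lower bound: the limit of > 50000 nM in this assay, at which 1 of the 3 values shown sits.

The compounds shown leave open whether the loss with compound 2 belongs to the chlorine itself or would also appear with another group on the phenyl ring, such as fluoro or methoxy in the same place, as in 4-fluorophenyl or 4-methoxyphenyl. They also leave open how this position would respond to a group of a different kind, such as an amine, a carboxylic acid or a saturated ring like cyclohexyl, in place of these aromatic groups.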